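The compounds below may be only part of what the source reports. "The series", "measured", "known", "first", "only" and "open" are said of these compounds alone.

Series notes. Compound 1 `Cc1ccc(S(=O)(=O)/N=C(/CCNC2=CC(=O)c3ccccc3C2=O)Nc2ccc(Cl)cc2)cc1` gives 7080 nM in a functional assay on MCF7 cells (Homo sapiens) for cytotoxicity, read by MTT assay, with a stated time of 48 h; a lower number here means a stronger inhibitor, a higher number a weaker inhibitor. Compound 2 `Cc1ccc(S(=O)(=O)/N=C(/CCNC2=CC(=O)c3ccccc3C2=O)Nc2ccccc2I)cc1` gives 15500 nM; the step is a 2.2-fold higher number from compound 1 to compound 2 (0.34 log units; beyond the scatter). Compound 3 `Cc1ccc(S(=O)(=O)/N=C(/CCNC2=CC(=O)c3ccccc3C2=O)Nc2ccc(F)c(F)c2)cc1` gives 9420 nM, the second highest of the three numbers, with both neighbours close: a 1.3-fold higher number from compound 1 to compound 3 (0.12 log units; within the scatter) and a 1.6-fold lower number from compound 2 to compound 3 (0.22 log units; within the scatter). Compound 4 `COc1cc(N/C(CCNC2=CC(=O)c3ccccc3C2=O)=N\S(=O)(=O)c2ccc(C)cc2)cc(OC)c1OC` is not yet measured; its change is 3,4,5-trimethoxyphenyl in place of 3,4-difluorophenyl on an amine nitrogen. The three measured steps all exchange the aryl group on this nitrogen, and only one of them went beyond the scatter, and that modestly. A comparably small step is therefore expected, with no clear direction. The estimated step is a 1.0-fold lower number from compound 3 to compound 4 (0.02 log units; within the scatter). For compound 4 the expected value in this assay is 9000 nM, within a range of 4000 nM to 22000 nM.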

Compound 4, half-maximal inhibitory concentration: 3050 nM
For compound 4 the middle estimate is 3.0-fold (0.47 log units) above the measured one; measured number below the stated range.
By their numbers in this assay, from the lowest: compound 4; then compounds 1, 3 and 2 (each within the scatter of the next, the first and the last beyond it).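

In this assay, the aryl group on this amine nitrogen now gives a step beyond the scatter against every earlier compound: a 3.1-fold lower number from compound 3 to compound 4 (0.49 log units; beyond the scatter), a 2.3-fold lower number from compound 1 to compound 4 (0.37 log units; beyond the scatter) and a 5.1-fold lower number from compound 2 to compound 4 (0.71 log units; beyond the scatter). Compound 4 therefore has the lowest number of the four, and the position is more responsive than the halogenated aryl groups showed. The change brings 3 hydrogen-bond acceptors where 3,4-difluorophenyl has 0, but nothing available ties the step to that count or to any other feature. As far as these compounds go, whether a pyridyl ring or a dimethylaminophenyl group on this nitrogen would lower the number further remains open.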